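This account rests on a few compounds, and the source may have more. Where it says the series, first, only, none or still open, it means among the compounds named here.

Measured so far in a functional assay on MCF7 cells (Homo sapiens) for antiproliferative activity, read by MTT assay, with a stated time of 72 h (on this read-out higher numbers stand for weaker inhibition and lower numbers for stronger inhibition), on this series:
- compound 1 `COc1cc(/C=C/c2ccc(C3=C(c4ccc(O)cc4)C4CC(S(=O)(=O)Oc5ccc(Br)cc5)C3O4)cc2)cc(OC)c1` gives > 100000 nM as a limit
- compound 2 `COc1cc(/C=C/c2ccc(C3=C(c4ccc(O)cc4)C4CC(S(=O)(=O)Oc5cccc(OC)c5)C3O4)cc2)cc(OC)c1` gives 77100 nM
- compound 3 `O=S(=O)(Oc1ccccc1Cl)C1CC2OC1C(c1ccc(/C=C/c3cc(O)cc(O)c3)cc1)=C2c1ccc(O)cc1` gives 40400 nM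

The value of compound 1 is a limit of > 100000 nM in this assay, at which 1 of the 3 values shown sits, and not a number. Compound 3 lies within the scatter of compound 2, its nearest neighbour on the numbers.

Compound 4 `Cc1cccc(OS(=O)(=O)C2CC3OC2C(c2ccc(/C=C/c4cc(O)cc(O)c4)cc2)=C3c2ccc(O)cc2)c1` comes from compound 3 through 3-methylphenyl in place of 2-chlorophenyl on an oxygen with 3-methylphenyl in place of 2-chlorophenyl on an oxygen. Among the measured compounds shown here, with an at least 1.2-fold lower number from compound 1 to compound 2 (0.11 log units; that floor lies within the scatter) as the one measured step at this place, carrying 3-methoxyphenyl in place of 4-bromophenyl on an oxygen, no direction follows and no change beyond the scatter is expected in this assay for compound 4. The estimated step is a 1.1-fold higher number from compound 3 to compound 4 (0.05 log units; within the scatter) and no more is expected. For compound 4 the estimate is 45000 nM with an expected range from 20000 nM to 100000 nM in this read-out.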

Compound 4, half-maximal inhibitory concentration: 16300 nM
Compound 4: the middle estimate sits 2.8-fold (0.44 log units) above what was measured; the whole stated range lies above it.
By their numbers in this assay, from the lowest: compound 4; then compounds 3 and 2 (each within the scatter of the next). At a limit, above all of these: compound 1.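

In this assay, among the compounds shown here, the swap of 2-chlorophenyl for 3-methylphenyl on the oxygen bonded to the sulfonyl sulfur gives a 2.5-fold lower number from compound 3 to compound 4 (0.39 log units; beyond the scatter) and is the first step at this place beyond the scatter. The swap changes both the substituent and where it sits on the ring, so the step cannot be divided between the two. No measured property of these compounds bears on this step.

A 3-chlorophenyl or 2-methylphenyl group here would separate those two changes. Going by these compounds, how an amine or a carboxylic acid on this ring would read remains open.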